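Hydroxy-aryl hydrazones of a morpholine sulfonamide benzamide

This account rests on a few compounds, and the source may have more. Where it says the series, first, only, none or still open, it means among the compounds named here.

Compound 1 `O=C(N/N=C/c1ccco1)c1cccc(S(=O)(=O)N2CCOCC2)c1`: > 100000 nM in a functional assay on MCF7 cells (Homo sapiens) for antiproliferative activity, read by MTT assay, with a stated time of 72 h; on this read-out lower numbers stand for stronger inhibition and higher numbers for weaker inhibition (a limit, not a number)
Compound 2 `COc1ccc(/C=N/NC(=O)c2cccc(S(=O)(=O)N3CCOCC3)c2)c(O)c1`: 5140 nM in this assay

For the measured compounds named here, compound 2 holds the only number in this assay; the other value is a limit (the limit of > 100000 nM in this assay, at which 1 of the 2 values shown sits). The measured step of an at least 19-fold lower number from compound 1 to compound 2 (1.28 log units; beyond the scatter) shows that the 2-hydroxy-4-methoxyphenyl group matters. Compound 3 `CCOc1cccc(/C=N/NC(=O)c2cccc(S(=O)(=O)N3CCOCC3)c2)c1O` differs from compound 2 by 3-ethoxy-2-hydroxyphenyl in place of 2-hydroxy-4-methoxyphenyl on a carbon with a double bond to nitrogen; the hydroxy stays and the alkoxy moves. Going by the values given here, no measured step isolates that change, so the step from compound 2 to compound 3 is expected to be a 1.0-fold lower number from compound 2 to compound 3 (0.01 log units; within the scatter) in this assay, within the scatter. Compound 3 is estimated at 5000 nM (range 1500 nM to 17000 nM).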

Compound 3, half-maximal inhibitory concentration: 19300 nM
Beside the measured number, compound 3's estimate is 3.9-fold (0.59 log units) below it; the whole stated range lies below it.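

Placing 3-ethoxy-2-hydroxyphenyl where compound 2 carries 2-hydroxy-4-methoxyphenyl gives a 3.8-fold higher number from compound 2 to compound 3 (0.57 log units; beyond the scatter), so on a carbon with a double bond to nitrogen, the hydroxyphenyl alone does not fix the number in this assay. Even so, the furan-2-yl group still compares poorly, with an at least 5.1-fold lower number from compound 1 to compound 3 (0.71 log units; beyond the scatter). That step is only a bound, as compound 1 holds a limit: the limit of > 100000 nM in this assay, at which 1 of the 3 values shown sits.

This change moves the alkoxy and lengthens it at once, so the two effects cannot be told apart. From the compounds shown here alone, how a 2-hydroxyphenyl without alkoxy, or one carrying an amine or a carboxylic acid, would read stays open.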